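Amide-nitrogen substituent in a triazole thioacetamide orexin-1 series

The compounds below may be only part of what the source reports. "The series", "measured", "known", "first", "only" and "open" are said of these compounds alone.

Measured so far in a functional assay on CHO cells for antagonist activity at Orexin/Hypocretin receptor type 1 (Homo sapiens), read by FLIPR and calcium flux; a lower number here means a stronger inhibitor, a higher number a weaker inhibitor:
Compound 1, `COc1ccc(C)cc1NC(=O)CSc1nnc(-c2ccoc2C)n1Cc1ccco1`: 2510 nM
Compound 2, `Cc1ccc(NC(=O)CSc2nnc(-c3ccoc3C)n2Cc2ccco2)cc1`: > 15800 nM, a limit of the assay, not a number
Compound 3, `Cc1occc1-c1nnc(SCC(=O)Nc2ccc(Cl)cc2)n1Cc1ccco1`: 2000 nM

Compound 2 sits at the limit of > 15800 nM in this assay, at which 1 of the 3 values shown sits, the only one of the three to do so. Its steps to the other two are both beyond the scatter: an at least 6.2-fold higher number from compound 1 to compound 2 (0.79 log units; beyond the scatter) and an at least 7.9-fold lower number from compound 2 to compound 3 (0.89 log units; beyond the scatter). Compounds 1 and 3 lie within the scatter of each other, a 1.3-fold lower number from compound 1 to compound 3 (0.10 log units; within the scatter).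

Compound 4, `Cc1occc1-c1nnc(SCC(=O)NN2CCc3ccccc32)n1Cc1ccco1`, is not yet measured. The change from compound 2 is 2,3-dihydro-1H-indol-1-yl in place of 4-methylphenyl on an amide-type nitrogen. Among the measured compounds shown here, the steps that bear on it are the two that alter the group on the amide-type nitrogen of compound 2, both at least modest, and both run toward lower numbers on leaving compound 2. For the measured compounds named here, no measured step places a 2,3-dihydro-1H-indol-1-yl on that nitrogen, so the size here is uncertain. A modest step toward a lower number in this assay is expected, though a second limit cannot be ruled out.

For compound 4 in this assay the estimate is 8000 nM, in the range 2000 nM to 30000 nM. Relative to compound 2 this estimate means an expected step of an at least 1.9-fold lower number from compound 2 to compound 4 (0.29 log units; that floor lies within the scatter).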

Compound 4, inhibition constant: > 15800 nM
Compound 4: no number, only a limit; the forecaster's own chance of this, stated with the estimate: 40%; middle value at least 1.9-fold (0.29 log units) from the limit.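

In this assay, compound 4 also stands at a limit, which is not a number, as compound 2 does: the limit of > 15800 nM in this assay, at which 2 of the 4 values shown sit. The step between these two compounds cannot be read, so the result gives no order between 2,3-dihydro-1H-indol-1-yl and 4-methylphenyl on the amide-type nitrogen. The new information lies in the other two comparisons, with an at least 7.9-fold higher number from compound 3 to compound 4 (0.89 log units; beyond the scatter) and an at least 6.2-fold higher number from compound 1 to compound 4 (0.79 log units; beyond the scatter), so 2,3-dihydro-1H-indol-1-yl, with its added five-membered ring and nitrogen, does not keep the readable values seen with 4-chlorophenyl and 2-methoxy-5-methylphenyl, and among the four compounds only those two groups give a number.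

From the compounds shown here alone, how far compounds 2 and 4 lie past the limit remains open, and so does any difference between them. Going by these compounds, it is also open whether 4-methoxyphenyl or piperidin-1-yl on the same nitrogen would give a readable value, which would help show how much of this position's tolerance depends on a directly attached phenyl ring and its substituents.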